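A few compounds are considered here, and "the series" means these few. Any claim that something is new, unique, unknown or untested is made for them only; others in the source may bear on it.

Three measured compounds share one core and differ only in the aryl group on a saturated ring carbon. In an in vivo ADME assay on the whole organism for pharmacokinetics, with Rattus norvegicus as the target, using cassette dosing (on this read-out higher numbers stand for fast clearance and lower numbers for slow clearance), compound 1 `Cc1ccc([C@@]2(O)C[C@H](C(=O)Nc3ccc(-n4ccccc4=O)cn3)N(C(=O)Nc3ccc(Cl)cc3)C2)cc1` gives 10.3 mL/min/kg, compound 2 `Cc1cccc([C@@]2(O)C[C@H](C(=O)Nc3ccc(-n4ccccc4=O)cn3)N(C(=O)Nc3ccc(Cl)cc3)C2)c1` gives 6.78 mL/min/kg and compound 3 `Cc1ccccc1[C@@]1(O)C[C@H](C(=O)Nc2ccc(-n3ccccc3=O)cn2)N(C(=O)Nc2ccc(Cl)cc2)C1` gives 5.12 mL/min/kg. Compound 3 stands at the low end of the three numbers, yet a 2.0-fold lower number from compound 1 to compound 3 (0.30 log units; within the scatter) and a 1.3-fold lower number from compound 2 to compound 3 (0.12 log units; within the scatter) both lie within the scatter, as does a 1.5-fold lower number from compound 1 to compound 2 (0.18 log units; within the scatter); moving the methyl around the phenyl ring produces nothing beyond scatter in this assay. Compound 4 `O=C(Nc1ccc(-n2ccccc2=O)cn1)[C@H]1C[C@](O)(c2ccc(F)c(F)c2)CN1C(=O)Nc1ccc(Cl)cc1` is not yet measured; it differs from compound 3 in that (3,4-difluorophenyl in place of 2-methylphenyl on a saturated ring carbon). Within the data shown here, no measured step exchanges a methylphenyl for a difluorophenyl, so the only steps that bear on it are the three methyl-position steps, all within the scatter, and they give no direction for a change of this kind. The step of a 1.2-fold higher number from compound 3 to compound 4 (0.07 log units; within the scatter) is therefore expected to stay within the scatter. Compound 4 is estimated at 6 mL/min/kg, with a range from 3 mL/min/kg to 12 mL/min/kg.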

Compound 4, clearance: 13.1 mL/min/kg
Beside the measured number, compound 4's estimate is 2.2-fold (0.34 log units) below it; the measured number lies above the stated range.
By their numbers in this assay, from the lowest: compounds 3, 2, 1 and 4 (each within the scatter of the next, the first and the last beyond it).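

In this assay, the aryl group on this saturated ring carbon now gives a step beyond the scatter (a 2.6-fold higher number from compound 3 to compound 4 (0.41 log units; beyond the scatter)), with 3,4-difluorophenyl in place of 2-methylphenyl. The same exchange stays within the scatter when made from the other two methylphenyl groups (a 1.9-fold higher number from compound 2 to compound 4 (0.29 log units; within the scatter) and a 1.3-fold higher number from compound 1 to compound 4 (0.10 log units; within the scatter)), so the position shows a modest response in one of three pairs, and that response depends on which methylphenyl serves as the starting point. Among these compounds, nothing available gives a reason for the one step beyond the scatter.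

On these data alone, it remains open whether that step follows from the two fluorines or from the loss of the 2-methyl group. The compounds shown also leave open how clearance responds to an unsubstituted phenyl, a single fluorine on the phenyl, or a saturated group such as cyclohexyl on this carbon.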